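A few compounds are considered here, and "the series" means these few. Any claim that something is new, unique, unknown or untested is made for them only; others in the source may bear on it.

Compound 1, `CCCSc1nc(N/N=C/c2ccc(Cl)cc2)c2nnn(Cc3ccccc3)c2n1`, is tested in a functional assay on MCF7 cells (Homo sapiens) for antiproliferative activity, read by MTT assay, with a stated time of 72 h (a higher number here means a weaker inhibitor, a lower number a stronger inhibitor), and compound 1 gives > 64000 nM, which is a limit of the assay rather than a number. Compound 2, `CCCSc1nc(N/N=C(\C)c2ccccc2)c2nnn(Cc3ccccc3)c2n1`, shares the core and differs on a nitrogen on an aromatic ring; in this assay compound 2 gives 32100 nM. For the measured compounds named here, the step of an at least 1.9-fold lower number from compound 1 to compound 2 (0.29 log units; that floor lies within the scatter) is the only measured step, and it rests on the limit of compound 1 (the limit of > 64000 nM in this assay, at which 1 of the 2 values shown sits), so its true size is open. Compound 3, `CCCSc1nc(N/N=C/c2c(O)ccc3ccccc23)c2nnn(Cc3ccccc3)c2n1`, carries the change (2-hydroxynaphthalen-1-yl in place of 4-chlorophenyl on a carbon with a double bond to nitrogen). Going by the values given here, no measured step covers this exchange; the step from compound 1 to compound 2 alters the same arm of the molecule but swaps a different group, so it offers only a loose guide that such swaps can move the number a little toward stronger inhibition. On that basis compound 3 is expected to sit near the upper end of the range, with the estimated step of an at least 1.4-fold lower number from compound 1 to compound 3 (0.15 log units; that floor lies within the scatter) modest and uncertain. For compound 3 the estimate in this assay is 45000 nM, within a range from 15000 nM to 130000 nM.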

Compound 3, half-maximal inhibitory concentration: 6400 nM
Beside the measured number, compound 3's estimate is 7.0-fold (0.85 log units) above it; measured number below the stated range.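

In this assay, 2-hydroxynaphthalen-1-yl in place of 4-chlorophenyl on a carbon with a double bond to nitrogen gives an at least 10-fold lower number from compound 1 to compound 3 (1.00 log units; beyond the scatter), the first step at this arm of the molecule that is shown to lie beyond the scatter, whereas the floor of an at least 1.9-fold lower number from compound 1 to compound 2 (0.29 log units; that floor lies within the scatter) could not show this. From the compounds shown here alone, compound 1 gives > 64000 nM, which is a limit and not a number, so only the floor of the new step is known and its true size remains open: the limit of > 64000 nM in this assay, at which 1 of the 3 values shown sits. The exchange brings in a second six-membered aromatic ring and a hydroxy group together, so this single step cannot divide its effect between them, and no cause for it can be named from these data.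

What the compounds shown leave open is whether an unsubstituted naphthalen-1-yl or a 2-hydroxyphenyl on that same carbon would reach the number of compound 3. Going by these compounds, it is also open whether a methoxy group or an amine could stand in place of the hydroxy group with the same result.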